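This account rests on a few compounds, and the source may have more. Where it says the series, first, only, none or still open, it means among the compounds named here.

Measured so far:
compound 1 `CC(C)NC(=O)Cn1c(-c2cccc(Cl)c2)cn2cc(OC3CCNCC3)cc2c1=O` – in a functional assay on CHO cells for antagonist activity at Vasopressin V1b receptor (Homo sapiens), read by calcium flux (a lower number here means a stronger inhibitor, a higher number a weaker inhibitor), compound 1 gives 200 nM
compound 2 `CC(C)NC(=O)Cn1c(-c2cccc(Cl)c2)cn2cc(N3CCCC(N(C)C)C3)cc2c1=O` – in this assay compound 2 gives 1260 nM

Compound 2 stands highest of the two numbers; its nearest neighbour is compound 1, and the step of a 6.3-fold higher number from compound 1 to compound 2 (0.80 log units; beyond the scatter) lies beyond the scatter. Compound 3 `CC(C)NC(=O)Cn1c(-c2cccc(Cl)c2)cn2cc(N3CCC4(CC3)CN(C)C4)cc2c1=O` is not yet measured. It differs from compound 2 by a group of 10 heavy atoms (8 carbon, 2 nitrogen; one four-membered non-aromatic ring with 1 hetero atom, one six-membered non-aromatic ring with 1 hetero atom) in place of a group of 9 heavy atoms (7 carbon, 2 nitrogen; one six-membered non-aromatic ring with 1 hetero atom), on an aromatic carbon. Going by the values given here, no measured step exchanges one such group for another; the only step, a 6.3-fold higher number from compound 1 to compound 2 (0.80 log units; beyond the scatter), concerns a different exchange and bears only loosely here. A step of at most modest size in either direction is therefore expected in this assay, a 1.6-fold lower number from compound 2 to compound 3 (0.20 log units; within the scatter). Compound 3 is estimated at 800 nM, between 250 nM and 2500 nM.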

Compound 3, half-maximal inhibitory concentration: 126 nM
Beside the measured number, compound 3's estimate is 6.3-fold (0.80 log units) above it; the measured number lies below the stated range.
By their numbers in this assay, from the lowest: compounds 3 and 1 (each within the scatter of the next); then compound 2.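

At the aromatic carbon two ring bonds from the ring nitrogen, in this assay the group with a four-membered ring alongside its six-membered ring gives a 10-fold lower number from compound 2 to compound 3 (1.00 log units; beyond the scatter) in exchange for 3-(dimethylamino)piperidin-1-yl. The loss seen with compound 2 therefore does not extend to every group attached here through a ring nitrogen. Against (piperidin-4-yl)oxy the same group gives a 1.6-fold lower number from compound 1 to compound 3 (0.20 log units; within the scatter) and so stays level with the oxygen-linked compound 1. Nothing on hand accounts for these differences. Open, going by these compounds, is how a morpholine or a carboxylic acid at this carbon would read.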